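A few compounds are considered here, and "the series" means these few. Any claim that something is new, unique, unknown or untested is made for them only; others in the source may bear on it.

Of the compounds shown here, two with a shared core have been measured, and a third awaits its number. Compound 1 `Cc1cc(C)c2cccc(OCc3c(Cl)ccc(S(=O)(=O)NC4(C(=O)N5CCN(C(=O)[C@@H](N)CCCC[N+](C)(C)C)CC5)CCCC4)c3Cl)c2n1` was examined in an assay on isolated protein for binding affinity to B1 bradykinin receptor (Homo sapiens); on this read-out lower numbers stand for stronger inhibition and higher numbers for weaker inhibition. In this assay compound 1 returns only a limit, < 10000 nM. Compound 2 `Cc1cc(C)c2cccc(OCc3c(Cl)ccc(S(=O)(=O)NC4(C(=O)N5CCN(C(=O)C[C@@H](N)CCC[N+](C)(C)C)CC5)CCCC4)c3Cl)c2n1` differs from it by a step that the two limits leave unreadable from compound 1 to compound 2. In this assay compound 2 likewise returns only a limit, < 10000 nM. Within the data shown here, both results sit at the limit of < 10000 nM in this assay, at which 2 of the 2 values shown sit, so compound 2 stands at a limit rather than at a number, and the single measured step between the two compounds cannot be read in size or direction. Compound 3 `Cc1cc(C)c2cccc(OCc3c(Cl)ccc(S(=O)(=O)NC4(C(=O)N5CCN(C(=O)CCC[N+](C)(C)C)CC5)CCCC4)c3Cl)c2n1` is reached from compound 2 by a group of 6 heavy atoms (5 carbon, 1 nitrogen; no ring) in place of a group of 9 heavy atoms (7 carbon, 2 nitrogen; no ring), on a saturated chain carbon bound to a carbonyl carbon. Among the measured compounds shown here, no measured step bears on this change, since the one step in hand is unreadable and compound 2 itself supplies only a limit. The step is therefore expected to be a step that the limit leaves unreadable from compound 2 to compound 3. Compound 3 is estimated at 3000 nM, within 300 nM to 30000 nM.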

Compound 3, inhibition constant: < 10000 nM
Compound 3 gave a limit, no number (the forecaster's own chance of this, stated with the estimate: 55%); the middle value lies beyond the limit too.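

Among these compounds, compound 3 also returns only a limit in this assay, so no step among compound 1, compound 2 and compound 3 can be read in size or direction: the limit of < 10000 nM in this assay, at which 3 of the 3 values shown sit.

The compounds shown leave open whether these three chains on the shared core differ at all in this assay, and by how much.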